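One group exchanged on the shared core

The source may report more compounds than this note shows. Statements on the series, on what has been measured and on what is new or still open speak of the compounds shown alone.

Measured in a functional assay on MV4-11 cells (Homo sapiens) for antiproliferative activity, read by resazurin assay, with a stated time of 72 h; on this read-out lower numbers stand for stronger inhibition of growth and higher numbers for weaker inhibition of growth:
compound 1 `CC(=O)N1CCN(c2ccc(Nc3nccc(-c4c[nH]c5cccnc45)n3)cc2)CC1` gives 420 nM
compound 2 `CC(=O)N1CCCN(c2cccc(Nc3nccc(-c4c[nH]c5ncccc45)n3)c2)CC1` gives 20 nM
compound 3 `CC(=O)N1CCCN(c2cccc(Nc3nccc(-c4c[nH]c5cccnc45)n3)c2)CC1` gives 688 nM

Compound 4 `CC(=O)N1CCN(c2ccc(Nc3nccc(-c4c[nH]c5ncccc45)n3)cc2)CC1` has not yet been measured. Compound 1 at 420 nM lies within the scatter of compound 3 at 688 nM, while compound 2 shows a much lower number at 20 nM. Compound 4 differs from compound 1 by one exchange: a group of 9 heavy atoms (7 carbon, 2 nitrogen; one five-membered aromatic ring with 1 hetero atom, one six-membered aromatic ring with 1 hetero atom) in place of a group of 9 heavy atoms (7 carbon, 2 nitrogen; one five-membered aromatic ring with 1 hetero atom, one six-membered aromatic ring with 1 hetero atom), on an aromatic carbon. For the measured compounds named here, the leaving group is the one compound 3 carries and the entering group the one compound 2 carries, so the one step that bears on it, run in reverse, is a 34-fold higher number from compound 2 to compound 3 (1.54 log units; beyond the scatter). Compounds 2 and 3 differ from compound 1 elsewhere too, so a large drop in this assay is expected, though perhaps not the full size. The estimated step is a 21-fold lower number from compound 1 to compound 4 (1.32 log units; beyond the scatter). Compound 4 is expected at 20 nM, within an estimated range of 6 nM to 70 nM.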

Compound 4, concentration for 50% growth inhibition: < 1 nM
Compound 4: a limit, no number; the forecaster's own chance of this, stated with the estimate: 1%; middle value at least 20-fold (1.30 log units) away from the limit.
By their numbers in this assay, from the lowest: compound 2; then compounds 1 and 3 (each within the scatter of the next). At a limit, below all of these: compound 4.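

In this assay compound 4 gives < 1 nM, which is a limit of the assay and not a number. On an aromatic carbon opposite the ring nitrogen, the exchange gives an at least 420-fold lower number from compound 1 to compound 4 (2.62 log units; beyond the scatter), so its size depends on the core that carries it: the same change on two cores in this assay, a 34-fold higher number (1.54 log units; beyond the scatter) from compound 2 to compound 3 and an at least 420-fold higher number (2.62 log units; beyond the scatter) from compound 4 to compound 1, at least 12-fold (1.08 log units) apart, beyond the scatter of two such steps That step rests on a limit, so its full size cannot be read: the limit of < 1 nM in this assay, at which 1 of the 4 values shown sits.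

The compounds shown leave open whether the exchange keeps this size when a primary amine or a carboxylic acid stands in place of the acetyl group.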